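The compounds below may be only part of what the source reports. "The series", "measured", "known", "first", "only" and "open" are said of these compounds alone.

Measured so far in a physicochemical assay for solubility, read by nephelometry, measured as kinetic solubility, at pH 2.0; a lower number here means a less soluble compound, a higher number a more soluble compound:
- compound 1 `NCc1csc(NC(=O)c2ccon2)n1`: 50 ug/mL
- compound 2 `CN(C)Cc1csc(NC(=O)c2cc(C(C)(C)C)nn2Cc2ccccc2)n1`: > 100 ug/mL, a limit of the assay
- compound 3 `CC(C)(C)c1cc(C(=O)Nc2ccccn2)n(Cc2ccccc2)n1`: 25 ug/mL

Compound 3 gives 25 ug/mL. The value of compound 1, 50 ug/mL, lies within the usual scatter of that number, so the two cannot be told apart. Compound 2 reports > 100 ug/mL, which is a limit and not a number.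

Compound 4 `Cc1csc(NC(=O)c2cc(C(C)(C)C)nn2Cc2ccccc2)n1` differs from compound 3 in one place: 4-methyl-1,3-thiazol-2-yl in place of pyridin-2-yl on an amide-type nitrogen. In words, 4-methyl-1,3-thiazol-2-yl stands in place of pyridin-2-yl on an amide-type nitrogen.

Among the compounds with values here, only one measured step bears on this change: an at least 4.0-fold lower number from compound 2 to compound 3 (0.60 log units; beyond the scatter). It does not carry over directly, since compound 2 holds 4-((dimethylamino)methyl)-1,3-thiazol-2-yl, whereas compound 4 holds the 4-methyl group and has no dimethylamino part. Within the data shown here, no measured step covers the exact swap, so no shift beyond the scatter is expected in this assay. The expected change is a 1.2-fold higher number from compound 3 to compound 4 (0.08 log units; within the scatter). For compound 4 the estimate is 30 ug/mL, with an expected range from 10 ug/mL to 80 ug/mL.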

Compound 4, solubility: < 1.6 ug/mL
Compound 4: no number, only a limit; the forecaster's own chance of this, stated with the estimate: 10%; middle value at least 18-fold (1.27 log units) from the limit.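

In this assay compound 4 gives < 1.6 ug/mL, which is a limit of the assay and not a number: the limit of < 1.6 ug/mL in this assay, at which 1 of the 4 values shown sits.

On the amide-type nitrogen, 4-methyl-1,3-thiazol-2-yl in place of pyridin-2-yl goes with an at least 15-fold lower number from compound 3 to compound 4 (1.19 log units; beyond the scatter), so the choice of ring at this position can matter a great deal, even though the opening comparison pointed to no change. With the 1,3-thiazol-2-yl ring kept, hydrogen in place of dimethylamino on the saturated chain carbon goes with an at least 62-fold lower number from compound 2 to compound 4 (1.79 log units; beyond the scatter), which shows that this ring alone does not go with the high reading of compound 2.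

As far as these compounds go, how far the true number of compound 4 lies past its limit stays open, so the full size of both steps is unknown. Also open, from the compounds shown here alone, is whether a morpholine or a carboxylic acid on that chain carbon would restore a high reading.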